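One More Methoxy Group, Tested on a Second Core

The source may report more compounds than this note shows. Statements on the series, on what has been measured and on what is new or still open speak of the compounds shown alone.

Of the compounds shown here, three have already been measured. Compound 1 `COc1ccc(/C=C/C2CC(=O)C=CO2)cc1` gives 149 uM in a functional assay on NCI-H460 cells (Homo sapiens) for inhibition, read by sulforhodamine B assay, with a stated time of 48 h; on this read-out higher numbers stand for weaker inhibition of growth and lower numbers for stronger inhibition of growth. Compound 2 `COc1ccc(/C=C/C2CC(=O)C=CO2)cc1OC` carries one additional methoxy group and gives 89.6 uM in this assay. The step of a 1.7-fold lower number from compound 1 to compound 2 (0.22 log units; within the scatter) corresponds to the change (methoxy in place of hydrogen on an aromatic carbon). Compound 3 `COc1ccc(/C=C/C2CC=CC(=O)O2)cc1` is built from the same atoms as compound 1, joined differently; the difference between the two cores is not broken down here. In this assay compound 3 gives 28.3 uM, the lowest of the three numbers, and its gap to each of the other two is beyond the scatter.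

Compound 4 `COc1ccc(/C=C/C2CC=CC(=O)O2)cc1OC` has not yet been measured. It differs from compound 3 by methoxy in place of hydrogen on an aromatic carbon, which is the same change, in the same place, that separates compound 1 from compound 2. The step from compound 3 to compound 4 is expected to be a 1.4-fold lower number from compound 3 to compound 4 (0.15 log units; within the scatter), a small shift comparable with the earlier one, because the same change produced a 1.7-fold lower number from compound 1 to compound 2 (0.22 log units; within the scatter). For compound 4 the estimated value in this assay is 20 uM, with a plausible range from 8 uM to 50 uM.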

Compound 4, concentration for growth inhibition (reported as GI): 14.6 uM
Compound 4: middle estimate off by 1.4-fold (0.14 log units), on the high side, within the range that was stated.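

In this assay, adding the methoxy group to the core of compound 3 gives a 1.9-fold lower number from compound 3 to compound 4 (0.29 log units; within the scatter), so this step alone is no larger than the differences seen between repeated measurements. Set beside the earlier step, the same change looks alike on both cores: the same change on two cores in this assay, a 1.7-fold lower number (0.22 log units; within the scatter) from compound 1 to compound 2 and a 1.9-fold lower number (0.29 log units; within the scatter) from compound 3 to compound 4, 1.2-fold (0.07 log units) apart, within the scatter of two such steps. This agreement shows that the small step carried over from one core to the other, but neither step on its own establishes a real effect of the methoxy group on growth inhibition, and two cores are too few to predict what a third would do.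

Among the compounds shown here, the only group added to the aromatic ring in these compounds is methoxy, so it remains open whether a hydroxyl group, an amine or a longer chain such as ethoxy in that place would give a step beyond the scatter. From the compounds shown here alone, it also remains open whether a carboxylic acid there would behave alike on both cores.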